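A few compounds are considered here, and "the series" means these few. Any claim that something is new, unique, unknown or untested is made for them only; others in the source may bear on it.

Compound 1 `CCCCCCOc1ccc(-c2c(C)[nH]c(=O)n2C2CCCCC2)cc1`: 8500 nM
Compound 2 `CCCCCCCOc1ccc(-c2c(C)[nH]c(=O)n2C2CCCCC2)cc1`: 11600 nM
Compound 3 `CCCCCCCCOc1ccc(-c2c(C)[nH]c(=O)n2C2CCCCC2)cc1`: 8500 nM

In a functional assay on brain (Rattus norvegicus, strain Wistar) for inhibition (on this read-out higher numbers stand for weaker inhibition and lower numbers for stronger inhibition), compound 1 and compound 3 share the same number, 8500 nM, and compound 2 stays within the scatter of both. Compound 4 `CCCCCCCCCCCCOc1ccc(-c2c(C)[nH]c(=O)n2C2CCCCC2)cc1` has a longer chain than compound 3: butyl in place of hydrogen on a saturated chain carbon, eight bonds along the chain from an oxygen on an aromatic ring. The closest evidence comes from earlier chain lengthening: a 1.4-fold higher number from compound 1 to compound 2 (0.14 log units; within the scatter), a 1.4-fold lower number from compound 2 to compound 3 (0.14 log units; within the scatter) and no change at the digits printed from compound 1 to compound 3 (within the scatter). None of these steps goes beyond the scatter, and they show no steady direction. The butyl addition is longer than any measured change, so the estimate stays uncertain, but no step beyond the scatter is expected. The expected step is a 1.1-fold higher number from compound 3 to compound 4 (0.02 log units; within the scatter). The estimate for compound 4 is 9000 nM, with an expected range from 3500 nM to 25000 nM.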

Compound 4, half-maximal inhibitory concentration: 52400 nM
Beside the measured number, compound 4's estimate is 5.8-fold (0.77 log units) below it, outside the stated range (above it).
By their numbers in this assay, from the lowest: compounds 1, 3 and 2 (each within the scatter of the next); then compound 4.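

Lengthening this chain does not stay neutral without limit in this assay: adding butyl at this position weakens inhibition (a 6.2-fold higher number from compound 3 to compound 4 (0.79 log units; beyond the scatter)), the first change in the series to go beyond the scatter. The comparisons with the two shorter chains agree (a 4.5-fold higher number from compound 2 to compound 4 (0.65 log units; beyond the scatter); a 6.2-fold higher number from compound 1 to compound 4 (0.79 log units; beyond the scatter)), so compound 4 is a weaker inhibitor than all three shorter compounds. No measurement shown here explains this loss.

Still open, as far as these compounds go, is where the loss begins, which a nonyl or decyl chain could help locate. Also open, from the compounds shown here alone, is whether a chain carrying an amine or a carboxylic acid would behave the same way.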